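The source may hold more compounds than are shown below. What is called first, only, known or untested is meant among the compounds shown, and "the series" means these compounds.

Working notes on the series. In a physicochemical assay for lipophilicity, at pH 7.4 (a higher number here means a more lipophilic compound, a lower number a more polar compound), compound 1 (`O=C(NC1CC1)C1CCN(c2cnccc2-c2ccccn2)CC1`) gives 1.3 while compound 2 (`CN(C)C(=O)C1CCN(c2cncnc2-c2ccc(F)cc2)CC1`) gives 1.9 and compound 3 (`Cc1cnn(-c2ccncc2N2CCC(C(=O)N(C)C)CC2)c1`) gives 1.6 as the starting point for the next step. Compound 3 lies within the scatter of both compound 1 and compound 2, so the three numbers fix its standing no more closely than that.

The step from compound 3 leads to compound 4 (`CN(C)C(=O)C1CCN(c2cnccc2-n2cc(C3CC3)cn2)CC1`) and puts cyclopropyl in place of methyl on an aromatic carbon. The same difference, cut one bond further out, reads 4-methyl-1H-pyrazol-1-yl to 4-cyclopropyl-1H-pyrazol-1-yl.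

Going by the values given here, no measured pair isolates this change, so the expectation rests on the structural change alone. An upward move in this assay is expected, and the estimated size is a number 0.40 log units higher from compound 3 to compound 4 (beyond the scatter) which would only just clear the usual scatter. For compound 4 the estimated value is 2 (expected range 1.7 to 2.4).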

Compound 4, distribution coefficient: 2.1
Compound 4: middle estimate off by 0.10 log units, on the low side; low and high end bracket the measured number.
By their numbers in this assay, from the lowest: compounds 1, 3, 2 and 4 (each within the scatter of the next, the first and the last beyond it).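

Cyclopropyl in place of methyl on an aromatic carbon of the five-membered aromatic ring gives the first comparison in the series that differs in one place. In this assay it reads a number 0.50 log units higher from compound 3 to compound 4 (beyond the scatter) and is a modest step, so this position is one where a change confined to the substituent, with no hydrogen-bond donor or acceptor entering or leaving, moves the number beyond the scatter. No supporting measurement bears on what lies behind the step.

With one pair, the compounds shown leave open whether the step follows the ring of the cyclopropyl or merely the larger carbon count, which a longer chain such as propyl at the same carbon would help separate. From the compounds shown here alone, how an amine or a carboxylic acid at this carbon would read in this assay also remains open.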